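The source may hold more compounds than are shown below. What is called first, only, known or untested is meant among the compounds shown, and "the series" means these compounds.

Measured so far:
compound 1, `CCc1nc(SC)c2n1CCN([C@@H](C(=O)NC)c1ccccc1)[C@H]2CCc1ccc(C(F)(F)F)cc1`, 85 nM
compound 2, `CCc1nc(C(C)C)c2n1CCN([C@@H](C(=O)NC)c1ccccc1)C2CCc1ccc(C(F)(F)F)cc1`, 10000 nM
compound 3, `CNC(=O)[C@@H](c1ccccc1)N1CCn2c(C)nc(Cl)c2[C@@H]1CCc1ccc(C(F)(F)F)cc1`, 90 nM

All three were tested in a functional assay on CHO cells for antagonist activity at Orexin/Hypocretin receptor type 1 (Homo sapiens), read by FLIPR and calcium flux; a higher number here means a weaker inhibitor, a lower number a stronger inhibitor. Compound 2 gives the highest number of the three, so it is the weakest inhibitor here; its gaps to compound 3 and to compound 1 both lie well beyond the scatter of repeated measurements. Among the compounds with values here, no two of the measured compounds differ in only one place, so no single step between them can be read off. Compound 4, `CCc1nc(OC)c2n1CCN([C@@H](C(=O)NC)c1ccccc1)C2CCc1ccc(C(F)(F)F)cc1`, has not been measured. It differs from compound 2 in one place: methoxy in place of isopropyl on an aromatic carbon. Compound 1 and compound 3 each carry a group smaller than isopropyl on the five-membered aromatic ring of the shared core, and in this assay compound 1 gives 85 nM while compound 3 gives 90 nM. On that basis a large step toward a lower number, far beyond the scatter, is expected from compound 2 to compound 4, a 33-fold lower number from compound 2 to compound 4 (1.52 log units; beyond the scatter). Compound 4 is therefore estimated at 300 nM, in a range from 60 nM to 2000 nM.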

Compound 4, half-maximal inhibitory concentration: 134 nM
Compound 4: the middle estimate sits 2.2-fold (0.35 log units) above what was measured, and the stated range covers the measured number.
By their numbers in this assay, from the lowest: compounds 1, 3 and 4 (each within the scatter of the next); then compound 2.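

In this assay, within the data shown here, the change of methoxy in place of isopropyl gives a 75-fold lower number from compound 2 to compound 4 (1.87 log units; beyond the scatter), the first step here made in one place alone. The earlier compounds shown here differ from one another in more than one place, so they could not tie the high number of compound 2 to its isopropyl; this pair can. It shows that, within this pair, the group on this aromatic carbon of the five-membered ring can by itself change the number by a large margin.

Because the step swaps one group for another, it cannot separate losing isopropyl from gaining the oxygen of methoxy, and it leaves open how an ethoxy group or an amine on this carbon would read. Nothing measured here explains the size of this step.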